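The source may report more compounds than this note shows. Statements on the series, on what has been measured and on what is new or still open speak of the compounds shown alone.

In a functional assay on MCF7 cells (Homo sapiens) for antiproliferative activity, read by sulforhodamine B assay, with a stated time of 48 h (on this read-out lower numbers stand for stronger inhibition and higher numbers for weaker inhibition), compound 1 (`COc1ccc(/C=C/C(=O)c2ccccc2-c2ccc(OC)c(OC)c2)cc1OC`) gives 4900 nM and compound 2 (`COc1ccc(OC)c(/C=C/C(=O)c2ccccc2-c2ccc(OC)c(OC)c2)c1`) gives 3100 nM, so compound 2 stands level with compound 1 within the scatter. Compound 3 (`COc1ccc(-c2ccccc2C(=O)/C=C/c2ccc(Br)cc2)cc1OC`) carries 4-bromophenyl in place of 2,5-dimethoxyphenyl on a double-bonded chain carbon bound to a double-bonded chain carbon. Within the data shown here, the only measured step at this place is a 1.6-fold lower number from compound 1 to compound 2 (0.20 log units; within the scatter), within the scatter, and it exchanges one dimethoxyphenyl for another, with no bromine tested. No step beyond the scatter, in either direction, is therefore expected, and the estimate is a 1.1-fold higher number from compound 2 to compound 3 (0.05 log units; within the scatter). Compound 3 is expected at 3500 nM, within an estimated range of 1200 nM to 10000 nM.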

Compound 3, half-maximal inhibitory concentration: 8300 nM
Compound 3: the middle estimate sits 2.4-fold (0.38 log units) below what was measured; measured number inside the range.
By their numbers in this assay, from the lowest: compounds 2, 1 and 3 (each within the scatter of the next, the first and the last beyond it).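

In this assay the place on a double-bonded chain carbon bound to a double-bonded chain carbon gives its first step beyond the scatter with 4-bromophenyl, as a 2.7-fold higher number from compound 2 to compound 3 (0.43 log units; beyond the scatter) contrasts with a 1.7-fold higher number from compound 1 to compound 3 (0.23 log units; within the scatter) within it. The exchange therefore reads as a modest loss only against 2,5-dimethoxyphenyl, not against 3,4-dimethoxyphenyl. No measured evidence accounts for this difference. As far as these compounds go, how an unsubstituted phenyl, 4-chlorophenyl or 4-aminophenyl would read at this place remains open.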